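The source may hold more compounds than are shown below. What is called first, only, known or untested is meant among the compounds shown, and "the series" means these compounds.

Measured so far in a functional assay for agonist activity at Glucose-dependent insulinotropic receptor (Homo sapiens); a lower number here means that less compound is needed, a higher number that more compound is needed for the effect:
compound 1, `Cc1noc(C2CCN(c3ncnc(Nc4ccc(S(C)(=O)=O)cc4)c3[N+](=O)[O-])CC2)n1`, gives 260 nM.
compound 2, `CCCc1noc(C2CCN(c3ncnc(Nc4ccc(S(C)(=O)=O)cc4)c3[N+](=O)[O-])CC2)n1`, gives 430 nM.
compound 3, `CC(C)(C)c1noc(C2CCN(c3ncnc(Nc4ccc(S(C)(=O)=O)cc4)c3[N+](=O)[O-])CC2)n1`, gives 1.5 nM.

Compound 3 has the lowest number of the three in this assay, and both steps leading to it are large: a 170-fold lower number from compound 1 to compound 3 (2.24 log units; beyond the scatter) and a 290-fold lower number from compound 2 to compound 3 (2.46 log units; beyond the scatter). The step of a 1.7-fold higher number from compound 1 to compound 2 (0.22 log units; within the scatter), by contrast, is within the scatter, so lengthening the chain on its own changed little, while the branched tert-butyl group changed a great deal.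

Compound 4, `CS(=O)(=O)c1ccc(Nc2ncnc(N3CCC(c4nc(-c5cccnc5)no4)CC3)c2[N+](=O)[O-])cc1`, is not yet measured. It differs from compound 3 by pyridin-3-yl in place of tert-butyl on an aromatic carbon. For the measured compounds named here, no measured step exchanges an alkyl group at this position for an aromatic ring, so the three steps above bear on compound 4 only indirectly: they show that this assay is highly sensitive to what sits on this carbon of the five-membered ring, and that the low number of compound 3 is tied to the tert-butyl group specifically. Removing that group is therefore expected to raise the number, though a ring may not fall back to where methyl or propyl stand.

Compound 4 is estimated at 30 nM in this assay, with a range of 3 nM to 300 nM, an expected step of a 20-fold higher number from compound 3 to compound 4 (1.30 log units; beyond the scatter).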

Compound 4, half-maximal effective concentration: 660 nM
Beside the measured number, compound 4's estimate is 22-fold (1.34 log units) below it; measured number above the stated range.
By their numbers in this assay, from the lowest: compound 3; then compounds 1, 2 and 4 (each within the scatter of the next, the first and the last beyond it).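

In this assay, the low number of compound 3 does not survive the exchange of tert-butyl for pyridin-3-yl on this carbon between the two ring nitrogen atoms, with a 440-fold higher number from compound 3 to compound 4 (2.64 log units; beyond the scatter) as a large step, so an aromatic ring does not stand in for the branched group here. For the compounds shown here, the ring instead falls in with the straight-chain compounds, since a 1.5-fold higher number from compound 2 to compound 4 (0.19 log units; within the scatter) stays within the scatter and a 2.5-fold higher number from compound 1 to compound 4 (0.40 log units; beyond the scatter) is only a modest step, which leaves tert-butyl as the one group of the four that stands far apart from the others and shows that this position is not served by just any group with more heavy atoms than methyl. Nothing at hand gives a measured property that would account for the gap between tert-butyl and pyridin-3-yl.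

The compounds shown leave open whether the low number needs tert-butyl itself or would also appear with other branched groups such as isopropyl or cyclobutyl. They also leave open whether the ring nitrogen of pyridin-3-yl matters, which a plain phenyl group on the same carbon would address.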